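The compounds below may be only part of what the source reports. "The series", "measured", "known", "first", "only" and "open" are said of these compounds alone.

In a functional assay on HCT-116 cells (Homo sapiens) for inhibition, read by colorimetric assay, with a stated time of 3 days (on this read-out lower numbers stand for stronger inhibition and higher numbers for weaker inhibition), compound 1 (`O=C(CCCCCCNC(=O)C(O)(O)C(F)(F)F)Nc1ncc(-c2ccc(Br)cc2)s1`) gives 2460 nM, compound 2 (`O=C(CCCCCCNC(=O)C(O)(O)C(F)(F)F)Nc1nc2ccccc2o1`) gives 3450 nM and compound 3 (`O=C(CCCCCCNC(=O)C(O)(O)C(F)(F)F)Nc1cccc(Br)c1`) gives 3060 nM. These three values lie within the scatter of one another, so compound 3 has no separate standing among them. Compound 4 (`O=C(CCCCCCNC(=O)C(O)(O)C(F)(F)F)Nc1nccs1`) carries 1,3-thiazol-2-yl in place of 3-bromophenyl on an amide-type nitrogen. Going by the values given here, the one measured step at this place, a 1.1-fold lower number from compound 2 to compound 3 (0.05 log units; within the scatter), exchanged 1,3-benzoxazol-2-yl for 3-bromophenyl and stayed within the scatter. No shift beyond the scatter, in either direction, is therefore expected in this assay. The estimated step is a 1.0-fold higher number from compound 3 to compound 4 (0.02 log units; within the scatter). For compound 4 the estimated value is 3200 nM, with an expected range of 1600 nM to 6500 nM.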

Compound 4, half-maximal inhibitory concentration: 10800 nM
For compound 4 the middle estimate is 3.4-fold (0.53 log units) below the measured one, and the stated range ends below it.
By their numbers in this assay, from the lowest: compounds 1, 3 and 2 (each within the scatter of the next); then compound 4.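

In this assay, going by these compounds alone, this position shows a step beyond the scatter for the first time: a 3.5-fold higher number from compound 3 to compound 4 (0.55 log units; beyond the scatter) and a 3.1-fold higher number from compound 2 to compound 4 (0.50 log units; beyond the scatter), both modest, so the group on the amide-type nitrogen is not freely exchangeable. Hydrogen in place of 4-bromophenyl on the aromatic carbon gives a 4.4-fold higher number from compound 1 to compound 4 (0.64 log units; beyond the scatter), which sets compound 4 apart from all three earlier compounds. No available evidence explains this shift. As far as these compounds go, what remains open is whether phenyl without bromine, or a methyl group, on that aromatic carbon of compound 4 would bring the number back within the scatter of compound 1.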